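A few compounds are considered here, and "the series" means these few. Any claim that something is new, unique, unknown or untested is made for them only; others in the source may bear on it.

Of the compounds shown here, three sharing one core have been tested so far. Compound 1 `CC(C)C(=O)OCCc1c(-c2ccccc2Cl)c2cc(Cl)ccc2[nH]c1=O` carries an isopropyl group on a carbonyl carbon; in an ADME assay on HepG2 2.2.15 cells (Homo sapiens) for cytotoxicity (a lower number here means that less compound is tolerated, a higher number that more compound is tolerated), compound 1 gives 62000 nM. Compound 2 `CCCCCCCC(=O)OCCc1c(-c2ccccc2Cl)c2cc(Cl)ccc2[nH]c1=O` has heptyl in place of isopropyl on that carbonyl carbon, and compound 2 gives 78000 nM. Compound 3 `CC(=O)OCC(=O)OCCc1c(-c2ccccc2Cl)c2cc(Cl)ccc2[nH]c1=O` has acetoxymethyl in place of isopropyl on the carbonyl carbon, and compound 3 gives 100000 nM. Compound 3 shows the highest of the three numbers, yet the gaps are small: the step of a 1.6-fold higher number from compound 1 to compound 3 (0.21 log units; within the scatter) and the step of a 1.3-fold higher number from compound 2 to compound 3 (0.11 log units; within the scatter) both lie within the scatter of repeated measurements, so the three compounds cannot be told apart in this assay.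

Compound 4 `CC(=O)N1CCC(C(=O)OCCc2c(-c3ccccc3Cl)c3cc(Cl)ccc3[nH]c2=O)CC1` is not yet measured. It differs from compound 3 in one place: 1-acetylpiperidin-4-yl in place of acetoxymethyl on a carbonyl carbon. Once more the exchange sits on the carbonyl carbon whose other neighbours are oxygen next to a carbonyl group. All earlier exchanges at that carbonyl carbon, a 1.3-fold higher number from compound 1 to compound 2 (0.10 log units; within the scatter), a 1.6-fold higher number from compound 1 to compound 3 (0.21 log units; within the scatter) and a 1.3-fold higher number from compound 2 to compound 3 (0.11 log units; within the scatter), stayed within the scatter. On that basis no step beyond the scatter is expected in this assay for compound 4. Compound 4 is therefore estimated at 100000 nM, with a range from 50000 nM to 200000 nM. This estimate means an expected step of no change at the digits printed from compound 3 to compound 4 (within the scatter).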

Compound 4, half-maximal cytotoxic concentration: 82000 nM
For compound 4 the middle estimate is 1.2-fold (0.09 log units) above the measured one, and the stated range covers the measured number.
By their numbers in this assay, from the lowest: compounds 1, 2, 4 and 3 (each within the scatter of the next).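

The carbonyl carbon whose other neighbours are oxygen next to a carbonyl group has so far carried only open chains, and compound 4 shows that it also accepts a ring: exchanging acetoxymethyl for 1-acetylpiperidin-4-yl, which brings a six-membered non-aromatic ring with 1 hetero atom and raises the group from 5 to 9 heavy atoms, gives a 1.2-fold lower number from compound 3 to compound 4 (0.09 log units; within the scatter) in this assay. The comparisons with the two simple alkyl esters read the same way, with a 1.1-fold higher number from compound 2 to compound 4 (0.02 log units; within the scatter) against heptyl and a 1.3-fold higher number from compound 1 to compound 4 (0.12 log units; within the scatter) against isopropyl, so all four compounds remain indistinguishable in this assay despite the added ring and its nitrogen. Nothing measured here offers an explanation for this flat result.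

Within the data shown here, still open is whether a carboxylic acid, a free amine or a phenyl ring on that same carbonyl carbon would produce the first step beyond the scatter. All four compounds also share the same core, including its two chlorine atoms, so these results say nothing about how exchanges elsewhere in the molecule would behave.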